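Benzoyl to ethoxycarbonyl on a weak antiproliferative core

The source may report more compounds than this note shows. Statements on the series, on what has been measured and on what is new or still open speak of the compounds shown alone.

Measured compounds:
compound 1 `Cc1c(C(=O)c2ccccc2)oc2ccc(NS(=O)(=O)c3ccc(F)cc3)cc12` — 24100 nM
compound 2 `Cc1c(C(=O)c2ccccc2)oc2ccc(NC(=O)c3ccc(F)cc3)cc12` — 31200 nM

Two compounds share the core of compound 1 `Cc1c(C(=O)c2ccccc2)oc2ccc(NS(=O)(=O)c3ccc(F)cc3)cc12` and have been measured in a functional assay on HepG2 cells (Homo sapiens) for antiproliferative activity, read by MTT assay, with a stated time of 48 h (a lower number here means a stronger inhibitor, a higher number a weaker inhibitor), where compound 1 gives 24100 nM and compound 2 gives 31200 nM. Compound 1 gives the lower of the two numbers, but the gap between the two lies within the scatter, so no order between them can be claimed.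

Compound 3 `CCOC(=O)c1oc2ccc(NS(=O)(=O)c3ccc(F)cc3)cc2c1C` is not yet measured. It differs from compound 1 by ethoxy in place of phenyl on a carbonyl carbon. Among the measured compounds shown here, no measured pair shows this change on this core, so nothing in the data fixes its direction or size. The step from compound 1 to compound 3 in this assay is expected to stay close to the scatter, a 1.5-fold higher number from compound 1 to compound 3 (0.16 log units; within the scatter), with a slight lean toward a higher number. Compound 3 is therefore expected to give about 35000 nM, within a range from 10000 nM to 100000 nM.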

Compound 3, half-maximal inhibitory concentration: 5680 nM
Beside the measured number, compound 3's estimate is 6.2-fold (0.79 log units) above it, and the stated range ends above it.
By their numbers in this assay, from the lowest: compound 3; then compounds 1 and 2 (each within the scatter of the next).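

In this assay, the group on the carbonyl carbon proves to be a place where the number responds, which compounds 1 and 2 could not show, as they differ elsewhere and no order between them can be claimed: ethoxy in place of phenyl gives a 4.2-fold lower number from compound 1 to compound 3 (0.63 log units; beyond the scatter). The aromatic ring of the benzoyl group is therefore not needed for activity on this core, and ethoxycarbonyl gives the stronger inhibitor, though the step is modest. No measurement shown here accounts for the step.

On these data alone, whether a carboxylic acid, or a longer chain such as butoxy, on the same carbonyl carbon would move the number further in this direction remains open. So does whether benzoyl to ethoxycarbonyl would give a similar step on compound 2.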